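Notes on amide-linked benzothiazoles in MCF7 cytotoxicity

The compounds below may be only part of what the source reports. "The series", "measured", "known", "first", "only" and "open" are said of these compounds alone.

Measured so far:
compound 1, `COc1ccc(-c2cc(C(=O)Nc3nc4ccc(F)cc4s3)nc3cc(-c4ccccc4)nn23)cc1OC`: 22400 nM
compound 2, `COc1ccc2nc(NC(=O)c3cc(-c4ccc(F)cc4)n4nc(-c5ccccc5)cc4n3)sc2c1`: 24500 nM

In a functional assay on MCF7 cells (Homo sapiens) for cytotoxicity, read by MTT assay, with a stated time of 48 h (on this read-out lower numbers stand for stronger inhibition and higher numbers for weaker inhibition), compound 2 gives 24500 nM, the highest of the two numbers measured. Its nearest neighbour is compound 1, which in this assay gives 22400 nM; the gap between the two lies within the scatter, so the pair shows no order. Compound 1 already carries a 3,4-dimethoxyphenyl group, and its number sits with that of compound 2.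

Compound 3, `COc1ccc2nc(NC(=O)c3cc(-c4ccc(OC)c(OC)c4)n4nc(-c5ccccc5)cc4n3)sc2c1`, is not yet measured in this assay. It differs from compound 2 by 3,4-dimethoxyphenyl in place of 4-fluorophenyl on an aromatic carbon. For the measured compounds named here, no step between two measured compounds isolates this change, so no direction beyond the scatter is expected: the estimated step is a 1.1-fold lower number from compound 2 to compound 3 (0.05 log units; within the scatter), a small move within the scatter. For compound 3 the expected value in this assay is 22000 nM, with a range from 9000 nM to 55000 nM.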

Compound 3, half-maximal inhibitory concentration: 18700 nM
Beside the measured number, compound 3's estimate is 1.2-fold (0.07 log units) above it, and the stated range covers the measured number.
By their numbers in this assay, from the lowest: compounds 3, 1 and 2 (each within the scatter of the next).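

In this assay, 3,4-dimethoxyphenyl in place of 4-fluorophenyl, on the aromatic carbon next to the ring nitrogen, gives a 1.3-fold lower number from compound 2 to compound 3 (0.12 log units; within the scatter), so this position accepts the larger group without a change that can be read. The second single change, methoxy in place of fluoro on an aromatic carbon, gives a 1.2-fold lower number from compound 1 to compound 3 (0.08 log units; within the scatter), so neither exchange separates these compounds in this assay. Nothing on hand bears on why the three numbers stay together.

Still open is whether any group at this position can move the number beyond the scatter, since the compounds shown carry only fluoro- or methoxy-substituted phenyl groups there. A carboxylic acid or an amine on that phenyl group would put this to the test, as would an unsubstituted phenyl group.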